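This account rests on a few compounds, and the source may have more. Where it says the series, first, only, none or still open, it means among the compounds named here.

The measured compounds, in an ADME assay on Huh-7 cells (Homo sapiens) for cytotoxicity; on this read-out higher numbers stand for lower toxicity in this test and lower numbers for higher toxicity in this test:

Compound 1, `Cc1ccccc1-c1nn(-c2ccccc2Cl)cc1CNCCN1CCN(C)CC1`. In this assay compound 1 reaches only the limit of > 20000 nM.
Compound 2, `COc1ccc(-n2cc(CNCCN3CCN(C)CC3)c(-c3ccccc3C)n2)cc1`. In this assay compound 2 likewise reaches only the limit of > 20000 nM.
Compound 3, `Cc1ccccc1-c1nn(-c2ccc(Br)cc2)cc1CNCCN1CCN(C)CC1`. In this assay compound 3 gives 9600 nM.

Within the data shown here, compound 3 therefore stands as the only compound with an actual number; the other two values are limits, as noted in the limit of > 20000 nM in this assay, at which 2 of the 3 values shown sit. The steps of an at least 2.0-fold lower number from compound 1 to compound 3 (0.31 log units; beyond the scatter) and an at least 2.0-fold lower number from compound 2 to compound 3 (0.31 log units; beyond the scatter) both run from a limit to this number, so each is at least modest, while a step that the two limits leave unreadable from compound 1 to compound 2 cannot be read at all.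

Compound 4 is `Cc1ccccc1-c1nn(-c2cccc(Cl)c2)cc1CNCCN1CCN(C)CC1`. It differs from compound 3 by 3-chlorophenyl in place of 4-bromophenyl on an aromatic nitrogen. Both steps that reach compound 3 replace a different aryl group on that nitrogen with 4-bromophenyl and both lower the number; compound 4 moves back toward a chlorophenyl, as in compound 1, though with the chlorine elsewhere on the ring. Compound 4 is therefore expected to show a somewhat higher number, a 1.6-fold higher number from compound 3 to compound 4 (0.19 log units; within the scatter), with a real chance of landing only at a limit. The estimate for compound 4 is 15000 nM, between 6000 nM and 40000 nM.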

Compound 4, half-maximal cytotoxic concentration: 16000 nM
The estimate for compound 4 lay 1.1-fold (0.03 log units) below the measured number; low and high end bracket the measured number.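

In this assay, the step of a 1.7-fold higher number from compound 3 to compound 4 (0.22 log units; within the scatter) means that the 3-chlorophenyl and 4-bromophenyl groups on this aromatic nitrogen cannot be told apart. The steps of an at least 1.2-fold lower number from compound 1 to compound 4 (0.09 log units; that floor lies within the scatter) and an at least 1.2-fold lower number from compound 2 to compound 4 (0.09 log units; that floor lies within the scatter) have floors that do not clear the scatter, so compound 4 is not separated from either compound, even though it gives an actual number where they reach only a limit. Both of these readings remain open-ended: the limit of > 20000 nM in this assay, at which 2 of the 4 values shown sit.

The compounds shown leave open whether the halogen itself or its place on the aryl ring matters at this nitrogen. They also leave open how a plain phenyl group, or an aryl group carrying an amine or a carboxylic acid, would read here.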